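The source may hold more compounds than are shown below. What is called first, only, known or untested is meant among the compounds shown, and "the series" means these compounds.

Working notes on the series. Compound 1 `Cc1cc(O)c(C2=NN(c3ccc(S(N)(=O)=O)cc3)C(c3ccccc3O)C2)cc1Cl` and compound 2 `COc1ccc(C2CC(c3cc(Cl)c(C)cc3O)=NN2c2ccc(S(N)(=O)=O)cc2)cc1OC` share one core, and in a functional assay on LOX IMVI cells (Homo sapiens) for antiproliferative activity, with a stated time of 48 h (on this read-out lower numbers stand for higher toxicity in this test and higher numbers for lower toxicity in this test), compound 1 gives 5870 nM, while compound 2 gives 37400 nM. Within the data shown here, compound 2 thus stands at the highest of the two numbers, and the only change so far, a 6.4-fold higher number from compound 1 to compound 2 (0.80 log units; beyond the scatter), is 3,4-dimethoxyphenyl in place of 2-hydroxyphenyl on a saturated ring carbon. Compound 3 `COc1ccc(C2CC(c3cc(Cl)c(C)cc3O)=NN2c2ccc(S(N)(=O)=O)cc2)c(OC)c1OC` remains to be measured; relative to compound 2 it differs by methoxy in place of hydrogen on an aromatic carbon, the aryl group going from 3,4-dimethoxyphenyl to 2,3,4-trimethoxyphenyl. Among the measured compounds shown here, no measured step bears directly on adding a methoxy to an aryl already carrying two; the one step known exchanges the whole aryl group. With nothing comparable recorded, compound 3 is expected to stay near compound 2, the step of a 1.2-fold higher number from compound 2 to compound 3 (0.08 log units; within the scatter) estimated as small and possibly within the scatter. The estimate for compound 3 in this assay is 45000 nM, with a range from 15000 nM to 130000 nM.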

Compound 3, concentration lethal to 50% of the cells: 8840 nM
Estimate against measurement, compound 3: 5.1-fold (0.71 log units) above, outside the stated range (below it).
By their numbers in this assay, from the lowest: compounds 1 and 3 (each within the scatter of the next); then compound 2.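

In this assay, methoxy in place of hydrogen on an aromatic carbon, ortho to a large group and ortho to a methoxy group, gives a 4.2-fold lower number from compound 2 to compound 3 (0.63 log units; beyond the scatter) as a beyond-scatter step, so this single position on the aryl group affects the read-out without exchange of the whole group. Exchanging the 2-hydroxyphenyl of compound 1 for the 2,3,4-trimethoxyphenyl of compound 3 gives a 1.5-fold higher number from compound 1 to compound 3 (0.18 log units; within the scatter) and leaves the two compounds within the scatter of each other, so the higher number of compound 2 is not shared by both methoxy-bearing aryl groups. No measurement at hand explains the step.

Going by these compounds, whether this response is specific to methoxy remains open, since an ethoxy group or an amine on the same carbon would test it. Also open, on these data alone, is whether a 2-methoxyphenyl group, without the other two methoxy groups, would give a similar number.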